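This account rests on a few compounds, and the source may have more. Where it says the series, first, only, none or still open, it means among the compounds named here.

Measured so far:
- compound 1, `O=S(=O)(CC1=NCCS1)C1C(c2ccccc2)=NN(c2ccccc2)C1c1ccccc1`, "not active" (no number reported)
- compound 2, `COc1ccc(C2=NN(c3ccccc3)C(c3ccc(C)cc3)C2S(=O)(=O)CC2=NCCO2)cc1`, 64.3%
- compound 3, `COc1ccc(C2=NN(c3ccccc3)C(c3ccc(C)cc3)C2S(=O)(=O)CC2=NCCS2)cc1`, 43.9%

In a functional assay, tested at 75 ug/mL (a higher number here means a stronger effect of the compound at the concentration tested, a lower number a weaker effect), compound 3 gives 43.9%, and compound 2 gives 64.3%. The change between them is a group of 5 heavy atoms (3 carbon, 1 nitrogen, 1 oxygen; one five-membered non-aromatic ring with 2 hetero atoms) in place of a group of 5 heavy atoms (3 carbon, 1 nitrogen, 1 sulfur; one five-membered non-aromatic ring with 2 hetero atoms), on a saturated chain carbon bound to a sulfonyl sulfur, and the step it made was a number 20.4 percentage points higher from compound 3 to compound 2 (beyond the scatter).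

Compound 4, `O=S(=O)(CC1=NCCO1)C1C(c2ccccc2)=NN(c2ccccc2)C1c1ccccc1`, carries the same change on the core of compound 1: a group of 5 heavy atoms (3 carbon, 1 nitrogen, 1 oxygen; one five-membered non-aromatic ring with 2 hetero atoms) in place of a group of 5 heavy atoms (3 carbon, 1 nitrogen, 1 sulfur; one five-membered non-aromatic ring with 2 hetero atoms), on a saturated chain carbon bound to a sulfonyl sulfur. The place is the same, so this is the same change. The difference between the two cores is not broken down here. In this assay compound 1 gives "not active" (no number reported).

From the earlier pair, a modest rise is expected for compound 4 as well, yet compound 1 starts from no reported activity, so the result may stay weak or again give no number. The value of compound 4 is estimated at 15%, expected between 0% and 40%.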

Compound 4, a percentage reported as activity, at one concentration (the size of the read-out at that concentration, not a potency): 45.5%
Compound 4: middle estimate off by 30.5 percentage points, on the low side; the whole stated range lies below it.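

In this assay compound 1 gives "not active" (no number reported) and compound 4 gives 45.5% so no step can be read between them. The compounds shown leave open how large this change is on the core of compound 1. Nothing shown accounts for the result.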